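Acetyl for hydrogen on an oxygen: two parallel pairs

The source may hold more compounds than are shown below. What is called first, only, known or untested is meant among the compounds shown, and "the series" means these compounds.

Compound 1 `O=C1C=C[C@]2(O)CCO[C@@H]2C1` gives 2.8 ug/mL in a functional assay on HeLa S3 cells (Homo sapiens) for cytotoxicity; a lower number here means a stronger inhibitor, a higher number a weaker inhibitor. Compound 2 `CC(=O)O[C@]12C=CC(=O)C[C@H]1OCC2` carries the change acetyl in place of hydrogen on an oxygen on a saturated carbon and in this assay compound 2 gives 4.1 ug/mL; the step is a 1.5-fold higher number from compound 1 to compound 2 (0.17 log units; within the scatter), so the acetyl neither strengthens nor weakens the measured effect in this pair.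

Compound 3 `OC1C=C[C@]2(O)CCO[C@@H]2C1` stands on a different core; the difference between the core of compound 1 and the core of compound 3 is not broken down here. In this assay compound 3 reaches only a limit, > 100 ug/mL, which is the limit of > 100 ug/mL in this assay, at which 1 of the 3 values shown sits.

Compound 4 `CC(=O)O[C@]12C=CC(O)C[C@H]1OCC2` is not yet measured. It differs from compound 3 by acetyl in place of hydrogen on an oxygen on a saturated carbon, the same change at the same place as between compound 1 and compound 2. The expectation for compound 4 rests on the pair of compound 1 and compound 2, where the step was a 1.5-fold higher number from compound 1 to compound 2 (0.17 log units; within the scatter), and on compound 3 giving only a limit. The expected step is a step that the limit leaves unreadable from compound 3 to compound 4. Compound 4 is therefore estimated at 150 ug/mL in this assay, between 50 ug/mL and 500 ug/mL, most probably reported again only as a limit.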

Compound 4, half-maximal inhibitory concentration: > 100 ug/mL
Compound 4 gave a limit, no number (the forecaster's own chance of this, stated with the estimate: 80%); the middle value lies beyond the limit too.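

Compound 3 and compound 4 both stand only at a limit in this assay, so no step can be read between them: the limit of > 100 ug/mL in this assay, at which 2 of the 4 values shown sit.

The compounds shown leave open whether acetyl in place of hydrogen has any effect on the core of compound 3, or stays within the scatter as in the pair of compound 1 and compound 2.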